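Aryl-triazole sulfides: ethoxy analogue after the fluoro compound

The source may hold more compounds than are shown below. What is called first, only, known or untested is meant among the compounds shown, and "the series" means these compounds.

Measured in a functional assay on the whole organism (strain Albino Wistar) for inhibition, with Rattus norvegicus as the target, read by paw edema, with stated times of 1 h and 5 h, at a dose of 10 mg/kg by the oral route; on this read-out lower numbers stand for less inhibition and higher numbers for more inhibition at the one dose given (going by the name of the read-out):
compound 1 `Clc1cccc(-n2cc(CSc3nc4ccccc4s3)nn2)c1`: 39.6%
compound 2 `Fc1ccc(-n2cc(CSc3nc4ccccc4s3)nn2)cc1`: 81.1%
compound 3 `Cc1ccccc1-n1cc(CSc2nc3ccccc3s2)nn1`: 43.4%

Compound 2 holds the highest of the three numbers in this assay; both others lie lower beyond the scatter (a number 37.7 percentage points lower from compound 2 to compound 3 (beyond the scatter), and compound 1 sits lowest, a number 41.5 percentage points higher from compound 1 to compound 2 (beyond the scatter)).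

Compound 4 `CCOc1ccc(-n2cc(CSc3nc4ccccc4s3)nn2)cc1` differs from compound 2 by ethoxy in place of fluoro on an aromatic carbon. Among the compounds with values here, no measured step swaps a substituent on a 4-fluorophenyl kept in place; the steps that bear are the exchanges of the whole aryl group on the aromatic nitrogen: a number 41.5 percentage points higher from compound 1 to compound 2 (beyond the scatter) and a number 37.7 percentage points lower from compound 2 to compound 3 (beyond the scatter), both large, while a number 3.8 percentage points higher from compound 1 to compound 3 (within the scatter) stays within the scatter. Every change away from 4-fluorophenyl so far cost a large amount, so a step downward in this assay is expected, though with wide uncertainty. Compound 4 is estimated at 55% (range 30% to 80%), an expected step of a number 26.1 percentage points lower from compound 2 to compound 4 (beyond the scatter).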

Compound 4, a percentage reported as inhibition, in the whole organism at one dose (the size of the read-out at that dose, not a potency): 34%
Beside the measured number, compound 4's estimate is 21 percentage points above it, and the stated range covers the measured number.
By their numbers in this assay, from the lowest: compounds 4, 1 and 3 (each within the scatter of the next); then compound 2.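

Within the data shown here, this is the first step that keeps the substituent at one place, para to a large group, and changes only the group: ethoxy in place of fluoro gives a number 47.1 percentage points lower from compound 2 to compound 4 (beyond the scatter) in this assay. Among these compounds, a substituent at this position therefore does not secure a high number, and the earlier steps, which changed group and place together, could not show that. No measured evidence accounts for the fall.

Going by these compounds, it remains open whether methoxy, chloro or an amine on the same carbon would read nearer compound 2 or compound 4.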